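Diaryl urea series: shift of the trifluoromethoxy end

This account rests on a few compounds, and the source may have more. Where it says the series, first, only, none or still open, it means among the compounds named here.

Measured in an assay on isolated protein for inhibition of serine/threonine-protein kinase 10 (Homo sapiens), read by thermal shift assay, tested at 10 uM; a higher number here means that the compound stabilises the target more against heat, a lower number that the compound stabilises the target less:
- compound 1 `CC(C)(C)c1cc(NC(=O)Nc2ccc(Cl)cc2)n(-c2ccc(OC(F)(F)F)cc2)n1`: 0 degrees C
- compound 2 `O=C(Nc1ccc(Cl)cc1)Nc1cc(C2CC2)nn1-c1ccc(OC(F)(F)F)cc1`: 0 degrees C

Compound 1 stands level with compound 2; the step from compound 1 to compound 2, cyclopropyl in place of tert-butyl on an aromatic carbon, gave no change at the digits printed from compound 1 to compound 2 (within the scatter). Compound 3 `CC(C)(C)c1cc(NC(=O)Nc2ccc(Cl)cc2)n(-c2ccc(NC(=O)C3CC3)cc2)n1` differs from compound 1 at the other aryl ring: (cyclopropylcarbonyl)amino in place of trifluoromethoxy on an aromatic carbon. Going by the values given here, no measured step touches this position, so the only comparison available is the unchanged pair above, which shows the shared core giving no shift. A change in this assay beyond the scatter is therefore not expected; the estimated step is no change at the digits printed from compound 1 to compound 3 (within the scatter). For compound 3 the expected value is 0 degrees C, within -1 degrees C to 2 degrees C.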

Compound 3, shift of the target's melting temperature: 3.4 degrees C
The estimate for compound 3 lay 3.4 degrees C below the measured number; the whole stated range lies below it.
By their numbers in this assay, from the lowest: compounds 1 and 2 (each within the scatter of the next); then compound 3.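

In this assay, the position held by trifluoromethoxy can move the read-out, which the unchanged pair of compound 1 and compound 2 could not show: (cyclopropylcarbonyl)amino there gives a number 3.4 degrees C higher from compound 1 to compound 3 (beyond the scatter) on the same core. The entering group brings both an amide and a cyclopropyl ring, and this single step does not separate the two. Nothing available bears on the reason for the rise.

Going by these compounds, whether the amide or the cyclopropyl ring carries the rise stays open. So does what a simple amine or a carboxylic acid would give at this position.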